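The source may hold more compounds than are shown below. What is called first, only, known or untested is meant among the compounds shown, and "the series" means these compounds.

Series notes. Compound 1 `O=C(c1cccc(OC(F)(F)F)c1)N1CCC(N(C2CC2)S(=O)(=O)c2cccc(C(F)(F)F)c2)CC1` and compound 2 `O=C(c1ccc(OC(F)(F)F)cc1)N1CCC(N(C2CC2)S(=O)(=O)c2cccc(C(F)(F)F)c2)CC1` share the same core and differ only in the ring attached to the carbonyl carbon. In an assay on HEK293 cells for inhibition of Voltage-dependent N-type calcium channel subunit alpha-1B (Homo sapiens), read by FLIPR and calcium flux, in the presence of a further agent that is not named here (a higher number here means a weaker inhibitor, a lower number a stronger inhibitor), compound 1 gives 370 nM, and in this assay compound 2 gives 300 nM. Among the compounds with values here, the step of a 1.2-fold lower number from compound 1 to compound 2 (0.09 log units; within the scatter) is the only measured step so far. Compound 2 therefore holds the lowest of the two numbers, with compound 1 close by within the scatter, so no ordering between the two can be claimed.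

Compound 3 `CS(=O)(=O)c1ccc(F)cc1C(=O)N1CCC(N(C2CC2)S(=O)(=O)c2cccc(C(F)(F)F)c2)CC1` is not yet measured. It differs from compound 2 as 5-fluoro-2-(methylsulfonyl)phenyl in place of 4-(trifluoromethoxy)phenyl on a carbonyl carbon. Within the data shown here, the one step that bears on it, a 1.2-fold lower number from compound 1 to compound 2 (0.09 log units; within the scatter), shifted a trifluoromethoxy group within the same kind of ring and changed little; the change to compound 3 replaces the ring substituents altogether, which that step does not cover. Among the measured compounds shown here, no measured step shows what a methylsulfonyl group together with a fluorine on this ring does. In this assay the expected step is a 2.0-fold higher number from compound 2 to compound 3 (0.30 log units; within the scatter), a modest move with a wide range. Compound 3 is estimated at 600 nM, with a range of 200 nM to 2000 nM.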

Compound 3, half-maximal inhibitory concentration: 560 nM
For compound 3 the middle estimate is 1.1-fold (0.03 log units) above the measured one, within the range that was stated.
By their numbers in this assay, from the lowest: compounds 2, 1 and 3 (each within the scatter of the next).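

In this assay, the position on a carbonyl carbon whose other neighbours are an amide-type nitrogen in a ring has so far been probed only by moving trifluoromethoxy around the ring, and a full change of ring substituents now gives a 1.9-fold higher number from compound 2 to compound 3 (0.27 log units; within the scatter) and a 1.5-fold higher number from compound 1 to compound 3 (0.18 log units; within the scatter) for 5-fluoro-2-(methylsulfonyl)phenyl in place of the two trifluoromethoxy-bearing phenyl groups. Both steps lie within the scatter, so at this position the three substituted phenyl groups cannot be told apart in this assay, even though the entering group shares no substituent with the groups it replaces. No supporting measurement accompanies this result that could account for it.

The contributions of the fluorine and the methylsulfonyl group stay unseparated, since they enter together, and a ring carrying only one of them would be needed to read each on its own. Also open, going by these compounds, is whether this position stays as flat with a carboxylic acid or an amine on the phenyl ring, or with a longer alkyl chain in place of the ring.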